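Moving a methoxy group around the ring beside the carbonyl

The compounds below may be only part of what the source reports. "The series", "measured", "known", "first", "only" and "open" are said of these compounds alone.

Compound 1 `COc1cc(OC)c(C(=O)/C=C/c2cn(-c3ccccc3)nc2-c2ccncc2)c(OC)c1`: in a functional assay on MCF7 cells (Homo sapiens) for inhibition, read by sulforhodamine B assay, with a stated time of 72 h (a lower number here means a stronger inhibitor, a higher number a weaker inhibitor), compound 1 gives 1600 nM
Compound 2 `COc1ccc(C(=O)/C=C/c2cn(-c3ccccc3)nc2-c2ccncc2)cc1OC`: in this assay compound 2 gives 4300 nM
Compound 3 `COc1ccc(OC)c(C(=O)/C=C/c2cn(-c3ccccc3)nc2-c2ccncc2)c1`: in this assay compound 3 gives 1400 nM

These three compounds share one core and differ only in how methoxy groups are arranged on the phenyl ring attached to the carbonyl carbon. Compound 3 has the lowest number of the three, but its gap to compound 1 lies within the scatter, so the two cannot be ranked against each other. Within the data shown here, the only single-place step among them is a 3.1-fold lower number from compound 2 to compound 3 (0.49 log units; beyond the scatter), a modest move toward stronger inhibition.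

Compound 4 `COc1ccc(C(=O)/C=C/c2cn(-c3ccccc3)nc2-c2ccncc2)c(OC)c1` has not yet been measured in this assay. It differs from compound 3 in that (2,4-dimethoxyphenyl in place of 2,5-dimethoxyphenyl on a carbonyl carbon). Among the measured compounds shown here, no measured pair shows exactly this rearrangement. What the data do show is that compound 2, which lacks a 2-methoxy group, is the weakest, while compound 1 and compound 3, which keep one, sit close together. Compound 4 keeps a 2-methoxy group, so its number is expected to stay close to compound 3, with the step of a 1.3-fold higher number from compound 3 to compound 4 (0.11 log units; within the scatter) estimated as small. Compound 4 is therefore expected to give roughly 1800 nM, in a range from 700 nM to 4500 nM.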

Compound 4, half-maximal inhibitory concentration: 8800 nM
For compound 4 the middle estimate is 4.9-fold (0.69 log units) below the measured one; measured number above the stated range.
By their numbers in this assay, from the lowest: compounds 3 and 1 (each within the scatter of the next); then compound 2; then compound 4.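

Moving one methoxy group, with the atoms otherwise unchanged, turns the 2,5-dimethoxyphenyl on the carbonyl carbon into 2,4-dimethoxyphenyl and gives a 6.3-fold higher number from compound 3 to compound 4 (0.80 log units; beyond the scatter) in this assay, so the place of that group matters and not just the number of methoxy groups on the ring. The earlier compounds shown here suggested that a 2-methoxy group might be enough to keep the number low, but compound 4 goes against this: it has one, yet the change from the 3,4-dimethoxyphenyl ring, which has none, gives a 2.0-fold higher number from compound 2 to compound 4 (0.31 log units; beyond the scatter), leaving compound 4 the weakest inhibitor of the four. The ring of compound 4 also shows that an added methoxy group can matter a great deal, since hydrogen in place of one methoxy group on the ring of compound 1 gives a 5.5-fold higher number from compound 1 to compound 4 (0.74 log units; beyond the scatter).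

No measurement shown here accounts for this sensitivity to arrangement. The compounds shown also leave open how this ring would respond to a group other than methoxy, such as an amine, a carboxylic acid or a longer chain like ethoxy, at the same ring carbons.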